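This account rests on a few compounds, and the source may have more. Where it says the series, first, only, none or still open, it means among the compounds named here.

Measured compounds in a functional assay on A549 cells (Homo sapiens) for antiproliferative activity; a higher number here means a weaker inhibitor of growth, a lower number a stronger inhibitor of growth:
compound 1 `c1ccc(-c2cc(-c3ccsc3)cc(-c3ccccn3)n2)nc1`: 0.62 ug/mL
compound 2 `c1ccc(-c2cc(-c3ccsc3)cc(-c3cccnc3)n2)nc1`: > 100 ug/mL, which is a limit of the assay and not a number.

For the measured compounds named here, compound 1 holds the only number in this assay; the other entry is a limit (the limit of > 100 ug/mL in this assay, at which 1 of the 2 values shown sits). Going by the values given here, the one measured step, an at least 160-fold higher number from compound 1 to compound 2 (2.20 log units; beyond the scatter), concerns a pyridin-2-yl group and is large. Compound 3 `c1ccc(-c2cc(-c3cccs3)cc(-c3ccccn3)n2)nc1` is not yet measured. It differs from compound 1 by thiophen-2-yl in place of thiophen-3-yl on an aromatic carbon; both pyridin-2-yl groups remain. The measured step moves a different group and does not bear on this change, and the two values for compound 1 and compound 2 give no hint on the thiophene. Among the compounds with values here, with no measured step touching the thiophene, no step beyond the scatter is expected for compound 3 in this assay, and the direction is open. Compound 3 is therefore estimated at 0.8 ug/mL in this assay, between 0.2 ug/mL and 3.5 ug/mL. The expected step is a 1.3-fold higher number from compound 1 to compound 3 (0.11 log units; within the scatter).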

Compound 3, concentration for 50% growth inhibition: 0.44 ug/mL
Compound 3: middle estimate off by 1.8-fold (0.26 log units), on the high side; measured number inside the range.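

In this assay, moving the point of attachment on the thiophene gives a step that does not separate the two isomers (a 1.4-fold lower number from compound 1 to compound 3 (0.15 log units; within the scatter)). For the compounds shown here, compound 3 is thus the first reading at this position, on an aromatic carbon opposite the ring nitrogen and meta to two pyridin-2-yl groups, whereas the earlier step concerned only a pyridin-2-yl group. Nothing measured here gives a reason for this result.

Only thiophen-2-yl and thiophen-3-yl are shown at this position, so it remains open whether a phenyl, an amine or a carboxylic acid would be accepted there. Also open, as far as these compounds go, is whether the two thiophene isomers would remain within the scatter of each other once a pyridin-2-yl group is replaced.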